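Bromo to Methyl on Two Related Cores

The compounds below may be only part of what the source reports. "The series", "measured", "known", "first", "only" and "open" are said of these compounds alone.

Compound 1 `COc1ccc(C2=C(c3ccc(SC)cc3)CC3CCCN3C2=O)cc1Br` and compound 2 `COc1ccc(C2=C(c3ccc(SC)cc3)CC3CCCN3C2=O)cc1C` share one core; in a functional assay on M14 cells (Homo sapiens) for cytotoxicity (a lower number here means a stronger inhibitor of growth, a higher number a weaker inhibitor of growth), compound 1 gives 3000 nM and compound 2 gives 200 nM. The change between them is methyl in place of bromo on an aromatic carbon, a step of a 15-fold lower number from compound 1 to compound 2 (1.18 log units; beyond the scatter). Compound 3 `CSc1ccc(C2=C(c3ccc(Br)cc3)C(=O)N3CCCC3C2)cc1` carries a core that differs from that of compound 1 by 4-bromophenyl in place of 3-bromo-4-methoxyphenyl on a double-bonded ring carbon; in this assay compound 3 gives 9000 nM, a step of a 3.0-fold higher number from compound 1 to compound 3 (0.48 log units; beyond the scatter) and of a 45-fold higher number from compound 2 to compound 3 (1.65 log units; beyond the scatter). Compound 4 `CSc1ccc(C2=C(c3ccc(C)cc3)C(=O)N3CCCC3C2)cc1` is unmeasured. It differs from compound 3 by methyl in place of bromo on an aromatic carbon, the same kind of change as in the first pair, but at a place that is not the same: para to a large group, rather than ortho to a methoxy group and meta to a large group. Compound 4 is expected to show a step of a 5.0-fold lower number from compound 3 to compound 4 (0.70 log units; beyond the scatter), smaller than the one seen because the place behind a 15-fold lower number from compound 1 to compound 2 (1.18 log units; beyond the scatter) is not repeated here. Compound 4 is estimated at 1800 nM, between 400 nM and 7000 nM.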

Compound 4, concentration for 50% growth inhibition: 6000 nM
For compound 4 the middle estimate is 3.3-fold (0.52 log units) below the measured one; low and high end bracket the measured number.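

In this assay, methyl in place of bromo does not carry over from one core to the other at the same size: the same change on two cores in this assay, a 15-fold lower number (1.18 log units; beyond the scatter) from compound 1 to compound 2 and a 1.5-fold lower number (0.18 log units; within the scatter) from compound 3 to compound 4, 10-fold (1.00 log units) apart, beyond the scatter of two such steps On the second core the change gives a 1.5-fold lower number from compound 3 to compound 4 (0.18 log units; within the scatter), while the two exchanges of the aromatic ring give a 30-fold higher number from compound 2 to compound 4 (1.48 log units; beyond the scatter) and a 2.0-fold higher number from compound 1 to compound 4 (0.30 log units; within the scatter). Among these compounds, with only two pairs, which differ in both the place of the change and the group around it, the data do not show which of these sets the size of the step.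

The compounds shown leave open whether the large step depends on the methoxy group kept on the ring of compound 2. They also leave open how an amine or a longer chain would fare at the place of the methyl.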